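Swapping a hydroxypropyl amide tail for a bare amine

The source may report more compounds than this note shows. Statements on the series, on what has been measured and on what is new or still open speak of the compounds shown alone.

Measured so far:
Compound 1, `O=C(N[C@@H](CO)C(=O)NO)c1ccc(C#Cc2ccccc2)cc1`, a physicochemical assay for lipophilicity; on this read-out lower numbers stand for lower lipophilicity and higher numbers for higher lipophilicity: 2
Compound 2, `COCCNC(=O)C[C@H](NC(=O)c1ccc(C#Cc2ccccc2)cc1)C(=O)NO`, this assay: 2
Compound 3, `O=C(C[C@H](NC(=O)c1ccc(C#Cc2ccccc2)cc1)C(=O)NO)NCCCO`, this assay: 2

Compound 3 stands level with compound 1 and compound 2 on this read-out. The measured steps all stay within the scatter: no change at the digits printed from compound 1 to compound 2 (within the scatter), no change at the digits printed from compound 1 to compound 3 (within the scatter) and no change at the digits printed from compound 2 to compound 3 (within the scatter). Each of those steps swaps one polar tail for another of similar size.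

Compound 4, `NC[C@H](NC(=O)c1ccc(C#Cc2ccccc2)cc1)C(=O)NO`, differs from compound 3 as follows: amino in place of (3-hydroxypropyl)carbamoyl on a saturated chain carbon, two bonds along the chain from an amide-type nitrogen and a carbonyl carbon. Among the measured compounds shown here, none of the measured steps covers the entry of an amino group, so they only show that rebuilding this tail among carbamoyl and hydroxy variants left the value unchanged. The step to a much smaller, nitrogen-only group is therefore expected to give a lower reading, with wide uncertainty: the step from compound 3 to compound 4 is estimated as a number 0.80 log units lower from compound 3 to compound 4 (beyond the scatter). Compound 4 is expected to give 1.2, in the range 0.2 to 2.2.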

Compound 4, distribution coefficient: 2
The estimate for compound 4 lay 0.80 log units below the measured number, within the range that was stated.
By their numbers in this assay, from the lowest: compounds 1, 2, 3 and 4 (each within the scatter of the next).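

In this assay, the tail can shrink sharply at this place on the saturated chain: with 7 heavy atoms leaving and 1 entering, amino in place of (3-hydroxypropyl)carbamoyl gives no change at the digits printed from compound 3 to compound 4 (within the scatter) and so adds a group with nitrogen as its only heavy atom to those already compared. Amino in place of (2-methoxyethyl)carbamoyl gives no change at the digits printed from compound 2 to compound 4 (within the scatter) and amino in place of hydroxy gives no change at the digits printed from compound 1 to compound 4 (within the scatter) as well, so among these four compounds neither the size of the group nor the arrival of amino shows up in the printed digits. No supporting measurement is available to explain this flat result.

On these data alone, whether the reading would stay level with a carboxylic acid or a dimethylamino group at this place remains open. A longer chain ending in an amine, such as 3-aminopropyl, is equally untested by the compounds shown.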